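Swapping the Phenol for a Carboxymethyl Group

A few compounds are considered here, and "the series" means these few. Any claim that something is new, unique, unknown or untested is made for them only; others in the source may bear on it.

Measured compounds:
compound 1 `CC1CCC(/C=N/c2ccccc2F)=C2NC=C(C(=O)O)C(=O)N21`: 14.5 umol/kg
compound 2 `CC1CCC(/C=N/c2ccc(O)cc2)=C2NC=C(C(=O)O)C(=O)N21`: 1.2 umol/kg

In a functional assay on the whole organism with Rattus norvegicus as the target (a higher number here means that more compound is needed for the effect, a lower number that less compound is needed), compound 2 gives the lower of the two numbers; the step of a 12-fold lower number from compound 1 to compound 2 (1.08 log units; beyond the scatter) is the only one recorded, and it shows that changing the group on the double-bonded nitrogen can move the dose strongly. Compound 3 `CC1CCC(/C=N/c2ccc(CC(=O)O)cc2)=C2NC=C(C(=O)O)C(=O)N21` differs from compound 2 in one place: carboxymethyl in place of hydroxy on an aromatic carbon. Going by the values given here, no measured step bears directly on this exchange, since the one known step concerns a different pair of groups. Its size only suggests that substituents on this ring matter, without pointing in a direction. The expectation for compound 3 is therefore a moderate rise in dose with wide uncertainty, a 2.5-fold higher number from compound 2 to compound 3 (0.40 log units; beyond the scatter). Compound 3 is estimated at 3 umol/kg, within the range from 0.8 umol/kg to 12 umol/kg.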

Compound 3, dose for 50% inhibition: 5.8 umol/kg
Beside the measured number, compound 3's estimate is 1.9-fold (0.29 log units) below it; measured number inside the range.
By their numbers in this assay, from the lowest: compound 2; then compound 3; then compound 1.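

In this assay, carboxymethyl in place of hydroxy on this aromatic carbon gives a 4.8-fold higher number from compound 2 to compound 3 (0.68 log units; beyond the scatter). The earlier step exchanged one ring substituent for another at a different place on the ring, whereas this one keeps the place, para to a large group, and changes only the group, so the group at this single position moves the dose on its own. Carboxymethyl brings 4 heavy atoms where hydroxy had 1, and the dose needed for compound 3 still stays in the low range spanned by this small set.

Nothing measured here explains why the number rises with this change. As far as these compounds go, whether the rise follows the carboxylic acid or the extra carbon that holds it remains open, and an amine, a methoxy group or a carboxylic acid set directly on the ring at this place would help to tell these apart.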